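A few compounds are considered here, and "the series" means these few. Any claim that something is new, unique, unknown or untested is made for them only; others in the source may bear on it.

Compound 2 `CN(C)c1ccc2c(=O)c(C(=O)Nc3cc(F)cc(F)c3)cn(-c3ccc(OCCCCCCC[n+]4ccccc4)cc3Cl)c2n1` was reported in an assay on LX2 cells for inhibition of COL1A1 promoter (Homo sapiens), read by a luciferase reporter, with a stated time of 24 h, tested at 20 uM (a higher number here means a stronger effect of the compound at the concentration tested, a lower number a weaker effect), as "not active" (no number reported), so no single number places it on the scale. A related compound, compound 1 `CN(C)c1ccc2c(=O)c(C(=O)Nc3cc(F)cc(F)c3)cn(-c3ccc(OCCCCCCC[N+]45CCN(CC4)CC5)cc3F)c2n1`, gives in this assay a reading of 9.02%, a weak effect. Compound 3 `CN(C)c1ccc2c(=O)c(C(=O)Nc3cc(F)cc(F)c3)cn(-c3ccc(OCCCCCCC[n+]4ccccc4)cc3F)c2n1` has not yet been measured. It differs from compound 2 by fluoro in place of chloro on an aromatic carbon. Among the measured compounds shown here, with no measured step of this kind to lean on, no shift beyond the usual scatter in this assay is expected from this change. Compound 3 is therefore expected to show 8% in this assay, within a range of 0% to 20%.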

Compound 3, a percentage reported as inhibition, at one concentration (the size of the read-out at that concentration, not a potency): 15.4%
Compound 3: the middle estimate sits 7.4 percentage points below what was measured; low and high end bracket the measured number.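

In this assay compound 2, with chloro, is reported as "not active" (no number reported) while compound 3, with fluoro on the same aromatic carbon, gives 15.4% and so shows that this position can carry a measurable reading. Exchanging the group at the chain end gives a number 6.4 percentage points higher from compound 1 to compound 3 (within the scatter) and so does not separate these two end groups. Nothing available explains these readings.
As far as these compounds go, whether bromo or methyl on this aromatic carbon would change the reading stays open. So does the effect of a longer chain or a trimethylammonium end group.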